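This account rests on a few compounds, and the source may have more. Where it says the series, first, only, none or still open, it means among the compounds named here.

Working notes on the triazole series in an assay on nucleic acid for inhibition of Nucleic Acid, read by fluorescence, tested at 100 uM; on this read-out lower numbers stand for less inhibition and higher numbers for more inhibition at the one concentration tested (going by the name of the read-out).

Compound 1 `CC(C)CCN(C)Cc1cn(CC(O)COC(=O)NCc2ccccc2)nn1` gives 26% in this assay. Compound 2 `CCCCCCCC(=O)OCC(O)Cn1cc(CN2CCN(c3ccccc3)CC2)nn1` gives 26% in this assay. Compound 2 thus stands level with compound 1 at the digits shown; the two values lie within the scatter of each other, and nothing about order can be drawn from them. Within the data shown here, compounds 1 and 2 differ in more than one place, so no single step between them is recorded, and the two values say only that both compounds sit at a modest level of inhibition.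

The next compound in the series is compound 3 `CCCCNC(=O)OCC(O)Cn1cc(CN2CCN(c3ccccc3)CC2)nn1`, which differs from compound 2 in one place: butylamino in place of heptyl on a carbonyl carbon. Among the measured compounds shown here, no measured step of this kind exists, so there is no basis for expecting a shift in either direction beyond the scatter. The expectation for the step from compound 2 to compound 3 is therefore no change at the digits printed from compound 2 to compound 3 (within the scatter), that is, no change beyond the scatter. Compound 3 is accordingly estimated at 26% in this assay, with a range from 10% to 42%.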

Compound 3, a percentage reported as inhibition, at one concentration (the size of the read-out at that concentration, not a potency): 11%
Compound 3: the middle estimate sits 15 percentage points above what was measured, within the range that was stated.
By their numbers in this assay, from the lowest: compound 3; then compounds 1 and 2 (each within the scatter of the next).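

At this position, on a carbonyl carbon whose other neighbours are oxygen next to a carbonyl group, the series now has its first readable step: in this assay, butylamino in place of heptyl gives a number 15 percentage points lower from compound 2 to compound 3 (beyond the scatter). The group at this place therefore bears on the read-out, which the level values of the two earlier compounds could not show, as they differ in more than one place. The step changes two things at once, the chain and the presence of a nitrogen with its hydrogen-bond donor, so heptylcarbonyl to butylcarbamoyl has to be read as one combined change, and no measurement at hand accounts for the lower number.

Still open, going by these compounds, is which part of the change goes with the lower number, and a plain butyl or a heptylamino group at the same carbonyl carbon would separate the chain from the nitrogen. Also open, on these data alone, is how far the trend runs, whether to a shorter chain such as ethylamino, a longer one such as octylamino, or a ring-bearing group such as benzylamino on the same core.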